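Adding a second methoxy to a weak sulfonamide

A few compounds are considered here, and "the series" means these few. Any claim that something is new, unique, unknown or untested is made for them only; others in the source may bear on it.

Measured so far:
- compound 1 `COc1cc(N(Cc2nc3ccccc3[nH]2)S(=O)(=O)c2ccc(C)cc2)cc(OC)c1OC`: 1020 nM
- compound 2 `Cc1ccc(N(Cc2nc3ccccc3[nH]2)S(=O)(=O)c2ccc(C)cc2)cc1`: 41300 nM
- compound 3 `COc1ccc(N(Cc2nc3ccccc3[nH]2)S(=O)(=O)c2ccc(C)cc2)cc1`: > 50000 nM

All three share a core and differ only in the substituents on one aromatic ring. In a functional assay on MGC-803 cells (Homo sapiens) for inhibition, read by MTT assay, with a stated time of 48 h (on this read-out lower numbers stand for stronger inhibition and higher numbers for weaker inhibition), compound 1 gives 1020 nM, while compound 2 gives 41300 nM. As far as these compounds go, for compound 3 the reading is only a limit of the assay, > 50000 nM, so its true number is unknown (the limit of > 50000 nM in this assay, at which 1 of the 3 values shown sits). Among the compounds with values here, the single measured step, an at least 1.2-fold higher number from compound 2 to compound 3 (0.08 log units; that floor lies within the scatter), is small and its floor lies within the usual scatter, so it gives little guidance.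

Compound 4 `COc1ccc(N(Cc2nc3ccccc3[nH]2)S(=O)(=O)c2ccc(C)cc2)cc1OC` differs from compound 3 by methoxy in place of hydrogen on an aromatic carbon. Within the data shown here, no measured step matches this change directly. What the numbers show is that compound 1, which carries three methoxy groups, sits far lower than either compound 2 or the limit of compound 3. Adding one methoxy is therefore expected to move compound 4 partway toward compound 1, a step of an at least 3.3-fold lower number from compound 3 to compound 4 (0.52 log units; beyond the scatter) in this assay. Compound 4 is estimated at 15000 nM, with a range from 3000 nM to 60000 nM, and a real chance that it too returns only a limit.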

Compound 4, half-maximal inhibitory concentration: > 50000 nM
Compound 4: no number, only a limit; the forecaster's own chance of this, stated with the estimate: 25%; middle value at least 3.3-fold (0.52 log units) away from the limit.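

Compound 4 returns only a limit in this assay, > 50000 nM. Compound 3 also sits at a limit, so the step that joins the two cannot be read: the limit of > 50000 nM in this assay, at which 2 of the 4 values shown sit.

What can be read is that one extra methoxy does not recover the level of the three-methoxy ring, and taking a methoxy away from that ring gives an at least 49-fold higher number from compound 1 to compound 4 (1.69 log units; beyond the scatter). Set against the 4-methylphenyl compound, the 3,4-dimethoxyphenyl ring gives an at least 1.2-fold higher number from compound 2 to compound 4 (0.08 log units; that floor lies within the scatter), a floor within the scatter, so no gain shows.

As far as these compounds go, the true values of compound 3 and compound 4 remain unknown. Also open, from the compounds shown here alone, is how an amine, a hydroxyl or a fluorine at this position would read, and whether any of them could stand in for the methoxy that separates compound 4 from compound 1.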